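Truncation of the benzyl arm: compound 2 to compound 3

The source may hold more compounds than are shown below. What is called first, only, known or untested is meant among the compounds shown, and "the series" means these compounds.

Of the compounds shown here, two have been measured in an assay for inhibition of MAP kinase-interacting serine/threonine-protein kinase 2 (Homo sapiens), read by luminescence and ADP-Glo, with a stated time of 2 h; on this read-out lower numbers stand for stronger inhibition and higher numbers for weaker inhibition. Compound 1 `O=c1ccc(-c2ccc3cn[nH]c3c2)cn1Cc1ccccc1Cl` gives 78 nM. Compound 2 `O=c1ccc(-c2ccc3cn[nH]c3c2)cn1Cc1cccc(F)c1` gives 38 nM. Among the compounds with values here, compound 2 stands at the lower of the two numbers; the single measured step, a 2.1-fold lower number from compound 1 to compound 2 (0.31 log units; beyond the scatter), exchanges one substituted aromatic ring for another on the saturated chain carbon bound to the aromatic nitrogen.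

Compound 3 `Cn1cc(-c2ccc3cn[nH]c3c2)ccc1=O` differs from compound 2 by hydrogen in place of 3-fluorophenyl on a saturated chain carbon bound to an aromatic nitrogen, so the aromatic ring carried on that carbon is lost and only a methyl remains on the aromatic nitrogen.

Within the data shown here, no measured step removes this ring. The step from compound 1 to compound 2 only swaps one ring pattern for another and shows a modest shift; it does not tell what the ring itself contributes. Losing the ring outright is a larger change than anything measured here. A move toward weaker inhibition, a higher number in this assay, is therefore expected for compound 3, of the size an 11-fold higher number from compound 2 to compound 3 (1.02 log units; beyond the scatter). With no direct anchor, the estimate for compound 3 is 400 nM, expected to lie between 100 nM and 2000 nM.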

Compound 3, half-maximal inhibitory concentration: > 2000 nM
Compound 3: a limit, no number (the forecaster's own chance of this, stated with the estimate: 10%); middle value at least 5.0-fold (0.69 log units) away from the limit.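

In this assay compound 3 gives > 2000 nM, which is a limit of the assay and not a number. Removing the aromatic ring from the saturated chain carbon bound to an aromatic nitrogen weighs far more than changing the ring's substitution: the loss of 3-fluorophenyl gives an at least 52-fold higher number from compound 2 to compound 3 (1.72 log units; beyond the scatter), and the loss of 2-chlorophenyl gives an at least 25-fold higher number from compound 1 to compound 3 (1.40 log units; beyond the scatter), whereas the exchange between the two rings gives only a 2.1-fold lower number from compound 1 to compound 2 (0.31 log units; beyond the scatter). Both large steps are lower bounds on the change, so the full cost of going from 3-fluorobenzyl to methyl stays unknown, but among the three compounds shown, only compound 1 and compound 2, which keep an aromatic ring at this place, give a number.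

What the compounds shown leave open is whether the aromatic ring itself is what counts, or whether a saturated carbon group such as cyclohexylmethyl or a longer chain than methyl would serve there as well. Going by these compounds, the reading for an unsubstituted benzyl also remains open, as does that for a benzyl carrying an amine or a carboxylic acid.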